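This account rests on a few compounds, and the source may have more. Where it says the series, first, only, none or still open, it means among the compounds named here.

Measured compounds:
- compound 1, `COc1ccccc1/C=c1\c(=O)[nH]/c(=C/c2cccc(Cl)c2Cl)c(=O)n1C`, 200 nM
- compound 2, `C=CCn1c(=O)/c(=C\c2cccc(F)c2)[nH]c(=O)/c1=C\c1ccccc1OC`, 13700 nM
- compound 3, `C=CCn1c(=O)/c(=C\c2cccc(Br)c2)[nH]c(=O)/c1=C\c1cccc(Br)c1`, "not active" (no number reported)

In a functional assay on MCF7 cells (Homo sapiens) for cytotoxicity, read by CCK-8 assay, with a stated time of 72 h (on this read-out lower numbers stand for stronger inhibition and higher numbers for weaker inhibition), compound 2 gives 13700 nM, the highest of the two numbers available. Its nearest neighbour is compound 1, which in this assay gives 200 nM, a gap that lies well beyond the usual scatter; compound 3 returned no number at all. For the measured compounds named here, no pair of measured compounds differs in a single place, so no measured step is available to calibrate the change that leads to compound 4, `C=CCn1c(=O)/c(=C\c2ccc(C)cc2)[nH]c(=O)/c1=C\c1ccccc1OC`. Compound 4 differs from compound 2 by 4-methylphenyl in place of 3-fluorophenyl on a double-bonded chain carbon bound to an aromatic carbon. Going by the values given here, nothing among the measured compounds isolates this exchange, so the size of the step in this assay cannot be read from the data; a change in either direction that stays within or only modestly exceeds the scatter seems most plausible. The step from compound 2 to compound 4 is estimated as a 1.1-fold lower number from compound 2 to compound 4 (0.06 log units; within the scatter). Compound 4 is accordingly expected to give about 12000 nM, within a range from 2500 nM to 60000 nM.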

Compound 4, half-maximal inhibitory concentration: "not active" (no number reported)
The entry for compound 4 holds no number, so the estimate cannot be set against anything.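

In this assay, for the compounds shown here, compound 4 carries no number, and no step from compound 2 to compound 4 can be read. No measured evidence bears on this result. The compounds shown leave open what exchanging 3-fluorophenyl for 4-methylphenyl alone does to the read-out.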